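Working notes: from compound 3 to compound 4

The compounds below may be only part of what the source reports. "The series", "measured", "known", "first", "only" and "open" are said of these compounds alone.

Measured so far in a functional assay on the whole organism (strain AKR) for inhibition, with Mus musculus as the target, read by paw edema, with a stated time of 3.5 h, at a dose of 0.01 mmol/kg by the intraperitoneal route; on this read-out lower numbers stand for less inhibition and higher numbers for more inhibition at the one dose given (going by the name of the read-out):
compound 1 `COc1ccc(OC)c(/C=C2\S/C(=N/c3nccs3)NC2=O)c1` gives 26%
compound 2 `Cc1ccc(/C=C2\S/C(=N/c3nccs3)NC2=O)cc1` gives 47%
compound 3 `O=C1N/C(=N\c2nccs2)S/C1=C\c1ccc(F)cc1` gives 65.6%

Compound 3 stands highest of the three numbers, with compound 2 nearest and compound 1 furthest below it. Among the measured compounds shown here, the only single-point step in the set is a number 18.6 percentage points higher from compound 2 to compound 3 (beyond the scatter), fluoro in place of methyl on an aromatic carbon.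

Compound 4 `O=C1N/C(=N\c2nccs2)S/C1=C\c1ccc(Br)cc1` differs from compound 3 by bromo in place of fluoro on an aromatic carbon. For the measured compounds named here, no measured step exchanges one halogen for another; the step from compound 2 to compound 3 only shows that the group at this aromatic carbon can move the read-out in this assay. A step close to the scatter is therefore expected for compound 4: a number 3.6 percentage points lower from compound 3 to compound 4 (within the scatter). Compound 4 is estimated at 62%, in the range 42% to 80%.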

Compound 4, a percentage reported as inhibition, in the whole organism at one dose (the size of the read-out at that dose, not a potency): 42.2%
For compound 4 the middle estimate is 19.8 percentage points above the measured one, within the range that was stated.
By their numbers in this assay, from the lowest: compound 1; then compounds 4 and 2 (each within the scatter of the next); then compound 3.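

In this assay the halogen on this aromatic carbon cannot be exchanged freely: bromo for fluoro gives a number 23.4 percentage points lower from compound 3 to compound 4 (beyond the scatter) and so removes the gain seen on going from methyl to fluoro. Bromo and methyl read alike here, with a number 4.8 percentage points lower from compound 2 to compound 4 (within the scatter) on this change. Nothing at hand accounts for the difference between fluoro and bromo.

On these data alone, whether chloro, an amine or a carboxylic acid on this carbon would stay near the fluoro compound remains open. As far as these compounds go, each number comes from a single dose, so potency also remains open.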